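A few compounds are considered here, and "the series" means these few. Any claim that something is new, unique, unknown or untested is made for them only; others in the source may bear on it.

Compound 1 `O=C(NNc1cccc(Cl)c1)c1ccc(NS(=O)(=O)c2cnc(O)nc2O)cc1`: 8410 nM
Compound 2 `O=C(NNc1ccccc1F)c1ccc(NS(=O)(=O)c2cnc(O)nc2O)cc1`: > 20000 nM

Both compounds were tested in a functional assay on OVCAR-3 cells (Homo sapiens) for antiproliferative activity, read by MTT assay, with a stated time of 24 h; on this read-out higher numbers stand for weaker inhibition and lower numbers for stronger inhibition. Compound 1 gives a true number there, 8410 nM. Compound 2 gives > 20000 nM, which is a limit of the assay and not a number. As far as these compounds go, it therefore stands at the limit of > 20000 nM in this assay, at which 1 of the 2 values shown sits, and how weak it really is remains unknown.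

Compound 3 `O=C(NNc1ccc(F)cc1)c1ccc(NS(=O)(=O)c2cnc(O)nc2O)cc1` keeps the shared core and carries 4-fluorophenyl in place of 2-fluorophenyl on an amine nitrogen. Going by the values given here, only one measured step bears on this change, and it also concerns the group on that amine nitrogen: an at least 2.3-fold higher number from compound 1 to compound 2 (0.37 log units; beyond the scatter). That step lies beyond the scatter, so swapping this group can shift the reading, but it involved a different pair of groups and gives only a rough guide. A modest step towards a lower number, meaning stronger inhibition, is expected, although the reading could well stay at the limit. The expected size of the change is an at least 1.3-fold lower number from compound 2 to compound 3 (0.12 log units; that floor lies within the scatter). For compound 3 the estimated value is 15000 nM, with an expected range from 6000 nM to 40000 nM.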

Compound 3, half-maximal inhibitory concentration: > 20000 nM
Compound 3 gave a limit, no number (the forecaster's own chance of this, stated with the estimate: 45%); middle value at least 1.3-fold (0.12 log units) from the limit.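

In this assay, the 4-fluorophenyl group on this amine nitrogen, like the 2-fluorophenyl group, reads weaker than 3-chlorophenyl, with an at least 2.3-fold higher number from compound 1 to compound 3 (0.37 log units; beyond the scatter). Compound 3 gives > 20000 nM, which is a limit of the assay and not a number, and the step between compound 2 and compound 3 cannot be read, so moving the fluorine around the ring shows no measurable effect in either direction. Of the three groups tried at this place, only the 3-chlorophenyl group of compound 1 gives a true number, and the other readings pile up at one end of the scale: the limit of > 20000 nM in this assay, at which 2 of the 3 values shown sit.

As far as these compounds go, it remains open how far compound 2 and compound 3 really lie from each other, and whether the loss seen from compound 1 follows from the change of halogen, from its place on the ring, or from both, as the two differ together in these compounds. A 3-fluorophenyl group would hold the place and change only the halogen, while a 4-chlorophenyl group would hold the chlorine and change only its place.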